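From carbamoyl to carboxy on the distal ring

The compounds below may be only part of what the source reports. "The series", "measured", "known", "first", "only" and "open" are said of these compounds alone.

Compound 1, `Cc1n[nH]c(C(=O)O)c1Cc1cccc(-c2ccccc2F)c1`, gives 900 nM in an assay on isolated protein for inhibition of 2-Hydroxyacid oxidase 2 (Rattus norvegicus); a lower number here means a stronger inhibitor, a higher number a weaker inhibitor.
Compound 2, `Cc1n[nH]c(C(=O)O)c1Cc1cccc(-c2ccc(C(N)=O)cc2)c1`, gives 200 nM in this assay.
Compound 3, `Cc1n[nH]c(C(=O)O)c1Cc1ccc(-c2ccc(C(F)(F)F)cc2)cc1`, gives 1100 nM in this assay.

Among the three measured compounds, compound 2 stands lowest in this assay. Compound 1 sits above it by a margin beyond the usual scatter, and compound 3 lies further still. No two of the measured compounds differ in a single place, so no isolated structural step can be read from these numbers, and nothing is known here about how any of them bind.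

Compound 4, `Cc1n[nH]c(C(=O)O)c1Cc1cccc(-c2ccc(C(=O)O)cc2)c1`, is the next compound to be measured. It differs from compound 2 in one place: hydroxy in place of amino on a carbonyl carbon. Put another way, carbamoyl becomes carboxy. Among the compounds with values here, with no measured pair of this kind to lean on, the expectation rests on compound 2 alone, at 200 nM, and on the smallness of the change. Compound 4 is expected to give about 400 nM, within 120 nM to 1500 nM. That estimate means a step of a 2.0-fold higher number from compound 2 to compound 4 (0.30 log units; within the scatter), expected to be modest, toward a weaker inhibitor, and quite possibly within the scatter.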

Compound 4, half-maximal inhibitory concentration: 1100 nM
Compound 4: the middle estimate sits 2.8-fold (0.44 log units) below what was measured; low and high end bracket the measured number.
By their numbers in this assay, from the lowest: compound 2; then compounds 1, 3 and 4 (each within the scatter of the next).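

Within the data shown here, the exchange of amino for hydroxy on a carbonyl carbon gives the first single-place comparison in this set, and in this assay it reads as a 5.5-fold higher number from compound 2 to compound 4 (0.74 log units; beyond the scatter) for this one change. This position therefore does not treat the two groups alike: with the rest of the structure held constant, carbamoyl goes with the lower number and carboxy with the higher, so the low standing of compound 2 depends on its amino part. Nothing at hand explains why the exchange has this effect.

The compounds shown leave open what else that carbonyl carbon would accept, for instance methylamino, dimethylamino or methoxy in place of the amino group. They also leave open whether removing the carbonyl group altogether, as in a nitrile, would preserve the number seen with carbamoyl.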